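A few compounds are considered here, and "the series" means these few. Any claim that something is new, unique, unknown or untested is made for them only; others in the source may bear on it.

Measured compounds:
compound 1 `COc1ccc(F)cc1CNCCCNc1ccnc2cc(Oc3ccc(C(C)(C)C)cc3)ccc12` — 7200 nM
compound 2 `COc1ccc(F)cc1CNCCCNc1ccnc2cc(Cc3cc(C)cc(C)c3)ccc12` — 940 nM

Both numbers come from an ADME assay on HepG2 cells (Homo sapiens) for cytotoxicity, read by luminescence, CellTiter-Glo and ATP content, with a stated time of 72 h; a higher number here means that more compound is needed for the effect, a lower number that less compound is needed. Among the measured compounds shown here, compound 2 holds the lowest of the two numbers; its nearest neighbour is compound 1, and the only step between them, a 7.7-fold lower number from compound 1 to compound 2 (0.88 log units; beyond the scatter), is a modest one that lies beyond the scatter.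

Compound 3 `COc1ccc(F)cc1CNCCCNc1ccnc2cc(-c3ccccc3)ccc12` is not yet measured. It differs from compound 2 in one place: phenyl in place of 3,5-dimethylbenzyl on an aromatic carbon

For the measured compounds named here, only one measured step touches the same aromatic carbon of the fused system, and that is a 7.7-fold lower number from compound 1 to compound 2 (0.88 log units; beyond the scatter). It shows that changing the group at this position can move this assay by a modest amount. Going by the values given here, no measured pair shows phenyl there. The expectation is therefore a modest step back toward a higher number, a 2.3-fold higher number from compound 2 to compound 3 (0.37 log units; beyond the scatter), with wide uncertainty. Compound 3 is estimated at 2200 nM, within a range of 700 nM to 7000 nM.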

Compound 3, half-maximal effective concentration: 2960 nM
For compound 3 the middle estimate is 1.3-fold (0.13 log units) below the measured one, within the range that was stated.
By their numbers in this assay, from the lowest: compound 2; then compound 3; then compound 1.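

In this assay, replacing 3,5-dimethylbenzyl with phenyl gives a 3.1-fold higher number from compound 2 to compound 3 (0.50 log units; beyond the scatter), so removing three carbons from this substituent while keeping one six-membered aromatic ring of carbon only still moves the number beyond the scatter. Replacing 4-(tert-butyl)phenoxy with phenyl gives a 2.4-fold lower number from compound 1 to compound 3 (0.39 log units; beyond the scatter), placing phenyl between the other two groups at this aromatic carbon. All three groups carry an aromatic ring of carbon only, so the presence of such a ring does not by itself set the number in this assay.

The compounds shown leave open how this carbon responds to a group with no aromatic ring, such as an amine, a carboxylic acid or a longer alkyl chain. No evidence is available to explain the differences among these three groups.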